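The compounds below may be only part of what the source reports. "The series", "measured", "known", "first", "only" and "open" are said of these compounds alone.

Compound 1 `COc1cc(-c2ncnn2-c2cccc(N)c2)cc(OC)c1OC` was tested in a functional assay on MCF7 cells (Homo sapiens) for antiproliferative activity, read by MTT assay, with a stated time of 72 h; a lower number here means a stronger inhibitor, a higher number a weaker inhibitor. Compound 1 gives > 10000 nM, which is a limit and not a number, so it stands at the limit of > 10000 nM in this assay, at which 2 of the 3 values shown sit. Compound 3 `CCOc1cccc(-c2ncnn2-c2cc(OC)c(OC)c(OC)c2)c1` gives > 10000 nM, which is also a limit. Compound 2 `COc1ccc(-c2ncnn2-c2cc(OC)c(OC)c(OC)c2)cc1` gives a true number, 360 nM. Compound 4 `COc1ccc(-n2ncnc2-c2cc(OC)c(OC)c(OC)c2)cc1` is still unmeasured. It differs from compound 1 by having 4-methoxyphenyl in place of 3-aminophenyl on an aromatic nitrogen. Within the data shown here, no measured step covers this change, so the guide is indirect. Compound 2 also carries a 4-methoxyphenyl group and reaches 360 nM, so a clear gain in strength is expected. The estimated step runs an at least 10-fold lower number from compound 1 to compound 4 (1.00 log units; beyond the scatter). For compound 4 the estimate is 1000 nM, with an expected range of 100 nM to 10000 nM.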

Compound 4, half-maximal inhibitory concentration: 7400 nM
Estimate against measurement, compound 4: 7.4-fold (0.87 log units) below, within the range that was stated.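

In this assay compound 4 gives a true number, 7400 nM, so the core with 4-methoxyphenyl on the aromatic nitrogen has activity that can be measured. Compound 1, with 3-aminophenyl there, gives only a limit, > 10000 nM. As far as these compounds go, the change is therefore read as an at least 1.3-fold lower number from compound 1 to compound 4 (0.13 log units; that floor lies within the scatter), so a real gain is possible, but its true size stays unknown.

From the compounds shown here alone, it remains open how the same core behaves with other groups on this nitrogen, such as a plain phenyl group or a hydroxyl-bearing phenyl group.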